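A few compounds are considered here, and "the series" means these few. Any claim that something is new, unique, unknown or untested is made for them only; others in the source may bear on it.

Of the compounds shown here, three sharing one core have been tested in a functional assay on UO-31 cells (Homo sapiens) for inhibition, read by sulforhodamine B assay, tested at 10 uM; a lower number here means less inhibition, a higher number more inhibition at the concentration tested (going by the name of the read-out). Compound 1, `COc1cc2oc(-c3cccc(NC(=O)c4cccc(Br)c4)c3)cc(=O)c2c(OC)c1OC`, carries an amide in one orientation; compound 2, `COc1cc2oc(-c3cccc(C(=O)Nc4ccc(C)cc4)c3)cc(=O)c2c(OC)c1OC`, and compound 3, `COc1cc2oc(-c3cccc(C(=O)Nc4ccc(Cl)cc4)c3)cc(=O)c2c(OC)c1OC`, carry the reversed amide with a different group on the outer ring. In this assay compound 1 is recorded as "active" (no number reported), a description without a figure. In this assay compound 2 gives 55.7%, and compound 3 gives 61.4%. The step of a number 5.7 percentage points higher from compound 2 to compound 3 (within the scatter) shows that the two figures lie within the scatter of one another, so compound 3 stands level with compound 2 on the numbers shown, and compound 1 offers no figure to compare.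

Compound 4, `COc1cc2oc(-c3cccc(C(=O)Nc4ccc(Cl)cc4)c3)cc(=O)c2c(O)c1OC`, differs from compound 3 only at the core: hydrogen in place of methyl on an oxygen on an aromatic ring. No measured step touches the core, so nothing shown bears directly on this change. With no guide, the expected step of a number 3.4 percentage points lower from compound 3 to compound 4 (within the scatter) is small, within the scatter. Compound 4 is therefore estimated at 58%, between 35% and 80%.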

Compound 4, a percentage reported as inhibition, at one concentration (the size of the read-out at that concentration, not a potency): 53%
Beside the measured number, compound 4's estimate is 5 percentage points above it, and the stated range covers the measured number.
By their numbers in this assay, from the lowest: compounds 4, 2 and 3 (each within the scatter of the next).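

Replacing methoxy with hydroxy on the shared core gives a number 8.4 percentage points lower from compound 3 to compound 4 (within the scatter) in this assay. Within the data shown here, the earlier step changed only a group on the outer ring, so this is the first reading on a change at the core, and it shows that the methyl on this oxygen can be removed without a difference that stands clear of the scatter. No measurement shown here offers an explanation for this result.

The compounds shown leave open how a longer chain on this oxygen, such as an ethoxy or propoxy group, would read, or an amine in place of the hydroxy. They also leave open whether replacing one of the other methoxy groups on the core with hydroxy would give a similar reading.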